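Swapping a methylphenyl for a halogenated phenyl on the shared core

The source may hold more compounds than are shown below. What is called first, only, known or untested is meant among the compounds shown, and "the series" means these compounds.

Measured compounds:
compound 1 `Cc1ccc(-c2nnc(COc3cnn(C(C)(C)C)c(=O)c3Cl)o2)cc1`: 3.01
compound 2 `Cc1cccc(-c2nnc(COc3cnn(C(C)(C)C)c(=O)c3Cl)o2)c1`: 3.02

In a physicochemical assay for lipophilicity (a higher number here means a more lipophilic compound, a lower number a more polar compound), compound 1 gives 3.01, the lowest of the two numbers, and its nearest neighbour is compound 2, where the step of a number 0.01 log units higher from compound 1 to compound 2 (within the scatter) stays within the scatter. Compound 3 `CC(C)(C)n1ncc(OCc2nnc(-c3cc(F)c(Cl)cc3Cl)o2)c(Cl)c1=O` has not yet been measured in this assay. It differs from compound 1 in one place: 2,4-dichloro-5-fluorophenyl in place of 4-methylphenyl on an aromatic carbon.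

For the measured compounds named here, the only measured step, from compound 1 to compound 2, moves a methyl group between positions on the same phenyl ring and does not touch chlorine or fluorine, so no measured step bears on this change. The expectation therefore rests on the counted difference alone: a methyl group leaves and two chlorine atoms and one fluorine atom enter, and the estimated step of a number 0.99 log units higher from compound 1 to compound 3 (beyond the scatter) is expected to be upward in this assay. For compound 3 the estimate is 4, with a range from 3.6 to 4.5.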

Compound 3, partition coefficient: 3.36
Beside the measured number, compound 3's estimate is 0.64 log units above it; measured number outside the range, below it.
By their numbers in this assay, from the lowest: compounds 1 and 2 (each within the scatter of the next); then compound 3.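

In this assay, the earlier pair had shown only that moving a methyl group around the phenyl ring leaves the number within the scatter. Compound 3 shows that this position, on an aromatic carbon of a five-membered aromatic ring with 2 nitrogen and 1 oxygen, can give a reading beyond the scatter when the substituents on that phenyl ring change in kind. The 2,4-dichloro-5-fluorophenyl group gives a number 0.35 log units higher from compound 1 to compound 3 (beyond the scatter), and against the other methylphenyl isomer it gives a step of much the same size, a number 0.34 log units higher from compound 2 to compound 3 (beyond the scatter). No supporting data explain the size of this change. The compounds shown do not separate the contribution of the two chlorine atoms from that of the fluorine atom, since all three enter together. They also leave open how this position would read with an amine or a carboxylic acid on the phenyl ring.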